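Replacing the bicyclic amide group of an inactive sulfone

A few compounds are considered here, and "the series" means these few. Any claim that something is new, unique, unknown or untested is made for them only; others in the source may bear on it.

Measured compounds:
compound 1, `O=C(NCc1ccc(S(=O)(=O)c2ccccc2)cc1)c1cc2ncccc2s1`, > 10000 nM
compound 2, `O=C(NCc1ccc(S(=O)(=O)c2cccc(C(F)(F)F)c2)cc1)c1cnc2nccn2c1`, 2 nM
compound 3, `O=C(NCc1ccc(S(=O)(=O)N2CCCCC2)cc1)c1cc2ccncc2o1`, 29 nM

In a functional assay on A2780 cells (Homo sapiens) for inhibition, read by sulforhodamine B assay, with a stated time of 72 h (on this read-out higher numbers stand for weaker inhibition and lower numbers for stronger inhibition), compound 1 gives only a limit, > 10000 nM, so its true value is not known; it sits at the limit of > 10000 nM in this assay, at which 1 of the 3 values shown sits. Within the data shown here, compound 2 gives 2 nM in this assay, and compound 3 gives 29 nM, so both lie well within the measured range, while compound 1 stands apart as the one compound without a number.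

Compound 4, `O=C(NCc1ccc(S(=O)(=O)c2ccccc2)cc1)c1ccc2nccn2c1`, has not been measured. It differs from compound 1 in one place, on a carbonyl carbon: a group of 9 heavy atoms (7 carbon, 2 nitrogen; one five-membered aromatic ring with 2 hetero atoms, one six-membered aromatic ring with 1 hetero atom) in place of a group of 9 heavy atoms (7 carbon, 1 nitrogen, 1 sulfur; one five-membered aromatic ring with 1 hetero atom, one six-membered aromatic ring with 1 hetero atom), on a carbonyl carbon. Among the measured compounds shown here, no step between two measured compounds matches this change, so its size cannot be read off directly. Since compound 1 is only a limit, any measurable value for compound 4 would appear as a gain of unknown size.

An improvement is expected for compound 4, with a step of an at least 66-fold lower number from compound 1 to compound 4 (1.82 log units; beyond the scatter), since compound 2, which carries a related group with one five-membered aromatic ring with 2 hetero atoms and gives 2 nM, shows that such groups can be strongly active. Compound 4 is thus estimated at 150 nM, between 10 nM and 3000 nM.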

Compound 4, half-maximal inhibitory concentration: 13 nM
For compound 4 the middle estimate is 12-fold (1.06 log units) above the measured one, and the stated range covers the measured number.
By their numbers in this assay, from the lowest: compound 2; then compound 4; then compound 3. At a limit, above all of these: compound 1.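

Among these compounds, compound 1 and compound 4 are the first pair here that differ in one place, so the group on the carbonyl carbon can now be judged with the rest of the molecule held constant: in this assay, the exchange gives an at least 760-fold lower number from compound 1 to compound 4 (2.88 log units; beyond the scatter). This position therefore separates a compound with a measurable value in the low range from one without a number, although the group that leaves and the group that enters have the same count of heavy atoms, hydrogen-bond donors and hydrogen-bond acceptors and no net charge, and differ in their atoms and in the five-membered aromatic ring, which has 1 hetero atom in the group that leaves and 2 hetero atoms in the group that enters. The value of compound 1 is a limit and not a number, so the size printed for this step is only a minimum: the limit of > 10000 nM in this assay, at which 1 of the 4 values shown sits.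

A single pair cannot show which difference between the two groups accounts for the gain, or whether the gain would carry over to a core other than that of compound 1. It also leaves open how a methyl group, a chlorine atom or an amine on the entering group would change the value.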